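A few compounds are considered here, and "the series" means these few. Any claim that something is new, unique, unknown or untested is made for them only; others in the source may bear on it.

Compound 1 `CCCCNc1nc(N)nc2c1CCN(S(C)(=O)=O)C2` gives 0.8 uM in an assay on HEK293 cells for agonist activity at Toll-like receptor 8 (Homo sapiens), read by a luciferase reporter, with a stated time of 6 h; on this read-out lower numbers stand for an effect already at smaller amounts and higher numbers for an effect only at larger amounts of compound.
Compound 2 `CCCCNc1nc(N)nc2c1CN(Cc1ccccc1Cl)CC2` gives 0.05 uM in this assay.
Compound 3 `CCCCNc1nc(N)nc2c1CN(Cc1ccc(-c3ccccc3)cc1)CC2` gives 0.5 uM in this assay.

Among the three measured compounds, compound 2 stands at the lowest number in this assay. Its nearest neighbour is compound 3, whose number is higher by a margin beyond the scatter, and compound 1 stands further away still, also beyond the scatter. Compound 2 is therefore the most potent of the three on this read-out.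

The unmeasured compound 4 `CCCCNc1nc(N)nc2c1CN(C(=O)c1cocn1)CC2` departs from compound 2 at one place: (1,3-oxazol-4-yl)carbonyl in place of 2-chlorobenzyl on an amine nitrogen in a ring. Among the measured compounds shown here, no measured pair shows this particular exchange, so the size of the step cannot be read from a known step. The two measured compounds that carry something other than the 2-chlorobenzyl group, compound 1 with 0.8 uM and compound 3 with 0.5 uM, both stand at higher numbers than compound 2, which suggests that the 2-chlorobenzyl group matters for the low number of compound 2. Compound 4 is thus expected to move to a higher number, with an estimated step of a 10-fold higher number from compound 2 to compound 4 (1.00 log units; beyond the scatter), beyond the scatter. For compound 4 the estimate in this assay is 0.5 uM, within a range from 0.1 uM to 2.5 uM.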

Compound 4, minimum effective concentration: 0.2 uM
Compound 4: the middle estimate sits 2.5-fold (0.40 log units) above what was measured; the measured number falls inside the stated range.
By their numbers in this assay, from the lowest: compound 2; then compound 4; then compounds 3 and 1 (each within the scatter of the next).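

In this assay the exchange of 2-chlorobenzyl for (1,3-oxazol-4-yl)carbonyl on the amine nitrogen in a ring gives a 4.0-fold higher number from compound 2 to compound 4 (0.60 log units; beyond the scatter), a modest step and the only one shown that changes this position alone. It shows that the position accepts a five-membered aromatic ring with 2 hetero atoms, joined through a carbonyl, in place of a six-membered aromatic ring of carbon only, at the cost of this step and no more. Nothing measured accounts for the size of the step.

The compounds shown leave open whether the step follows the carbonyl or the ring, which a 2-chlorobenzoyl or a (1,3-oxazol-4-yl)methyl group on this nitrogen would separate. Going by these compounds, how a simple acetyl group or a pyridine-bearing carbonyl would stand here also remains open.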